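Shortening the side chain of an adenosine receptor ligand

The source may report more compounds than this note shows. Statements on the series, on what has been measured and on what is new or still open speak of the compounds shown alone.

Compound 1 `CCCCC/C=C/C=C/C=N/Nc1nc(N)c2ncn([C@@H]3O[C@H](CO)[C@@H](O)[C@H]3O)c2n1`: 2 nM
Compound 2 `Nc1nc(N/N=C/c2ccc(-c3ccc(Br)cc3)o2)nc2c1ncn2[C@@H]1O[C@H](CO)[C@@H](O)[C@H]1O`: 4.5 nM
Compound 3 `Nc1nc(N/N=C/c2cccc(OCc3ccccc3)c2)nc2c1ncn2[C@@H]1O[C@H](CO)[C@@H](O)[C@H]1O`: 13 nM

Three compounds that share one core, and differ only in the group hanging from the hydrazone, have been tested in an assay on CHO-K1 cells for displacement of a labelled ligand from adenosine receptor A1 (Homo sapiens), read by scintillation counting, with a stated time of 60 min; on this read-out higher numbers stand for weaker inhibition and lower numbers for stronger inhibition. Compound 1 gives 2 nM, the lowest number of the three and therefore the strongest inhibition; compound 2 gives 4.5 nM and compound 3 gives 13 nM, both beyond the usual scatter above compound 1. So compound 1 is the best starting point, and the question is what happens when its long chain is replaced by a much shorter one.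

Compound 4 `CSCC/C=N/Nc1nc(N)c2ncn([C@@H]3O[C@H](CO)[C@@H](O)[C@H]3O)c2n1` is that shorter analogue. Relative to compound 1 the change is a group of 4 heavy atoms (3 carbon, 1 sulfur; no ring) in place of a group of 9 heavy atoms (9 carbon; no ring), on a carbon with a double bond to nitrogen. Going by the values given here, no pair measured so far differs in the same way, so the size of the effect has to be guessed from general experience: the entering group is smaller than the one it replaces, and both of the larger companions, compound 2 and compound 3, sit weaker than compound 1. A moderate loss rather than a gain is expected, and the step is estimated at a 15-fold higher number from compound 1 to compound 4 (1.18 log units; beyond the scatter). Compound 4 is therefore estimated at 30 nM, with a plausible range from 8 nM to 150 nM.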

Compound 4, inhibition constant: > 10000 nM
Compound 4: a limit, no number (the forecaster's own chance of this, stated with the estimate: 2%); middle value at least 330-fold (2.52 log units) away from the limit.
By their numbers in this assay, from the lowest: compound 1; then compound 2; then compound 3. At a limit, above all of these: compound 4.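

In this assay compound 4 gives > 10000 nM, which is a limit of the assay and not a number. The three earlier compounds carry very different large groups on the hydrazone, yet all give low numbers, so they gave no sign that a change here could remove measurable binding; replacing the group of 9 carbon atoms with 2-(methylsulfanyl)ethyl now produces an at least 5000-fold higher number from compound 1 to compound 4 (3.69 log units; beyond the scatter), showing that this place on the carbon with a double bond to nitrogen can decide between strong inhibition and no inhibition that can be given a number. That step is a lower bound, and its real size cannot be read, since compound 4 gives a limit rather than a number: the limit of > 10000 nM in this assay, at which 1 of the 4 values shown sits.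

The change alters several things at once: the chain becomes shorter, it loses its 2 double bonds, and it gains a sulfur, so the compounds shown cannot tell which of these matters. A plain butyl chain or a saturated octyl chain in the same place would begin to separate chain length from the double bonds and the sulfur.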